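Growth inhibition from compound 3 to compound 4

The source may report more compounds than this note shows. Statements on the series, on what has been measured and on what is new or still open speak of the compounds shown alone.

Compound 1 `Oc1cccc2[nH]c(-c3ccc(-c4ccc(-c5ccc(F)cc5)cc4)cc3)nc12` gives 9100 nM
Compound 2 `Oc1cccc2[nH]c(-c3ccc(-c4ccc(-c5ccc(OC(F)(F)F)cc5)cc4)cc3)nc12` gives 8410 nM
Compound 3 `CN(C)c1ccc(-c2ccc(-c3ccc(-c4nc5c(O)cccc5[nH]4)cc3)cc2)cc1` gives 6240 nM

In a functional assay on SiHa cells (Homo sapiens) for inhibition, read by sulforhodamine B assay (on this read-out higher numbers stand for weaker inhibition of growth and lower numbers for stronger inhibition of growth), compound 3 gives 6240 nM, level with the other two within the scatter. Compound 4 `Oc1cccc2[nH]c(-c3ccc(-c4ccc(-c5cccc(Cl)c5)cc4)cc3)nc12` has 3-chlorophenyl in place of 4-(dimethylamino)phenyl on an aromatic carbon. Among the compounds with values here, no measured compound carries this group. The nearest evidence is the group exchanges already measured, a 1.1-fold lower number from compound 1 to compound 2 (0.03 log units; within the scatter), a 1.5-fold lower number from compound 1 to compound 3 (0.16 log units; within the scatter) and a 1.3-fold lower number from compound 2 to compound 3 (0.13 log units; within the scatter), all within the scatter, so no step beyond it is expected. The estimated step is a 1.2-fold higher number from compound 3 to compound 4 (0.08 log units; within the scatter). Compound 4 is expected at 7500 nM. Its estimated range runs from 3800 nM to 14000 nM.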

Compound 4, concentration for 50% growth inhibition: 8400 nM
Compound 4: the middle estimate sits 1.1-fold (0.05 log units) below what was measured; low and high end bracket the measured number.
By their numbers in this assay, from the lowest: compounds 3, 4, 2 and 1 (each within the scatter of the next).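

In this assay, 3-chlorophenyl on this aromatic carbon stays within the scatter against 4-(dimethylamino)phenyl (a 1.3-fold higher number from compound 3 to compound 4 (0.13 log units; within the scatter)), against 4-(trifluoromethoxy)phenyl (a 1.0-fold lower number from compound 2 to compound 4 (0.00 log units; within the scatter)) and against 4-fluorophenyl (a 1.1-fold lower number from compound 1 to compound 4 (0.03 log units; within the scatter)). The earlier compounds shown here covered only 4-substituted phenyl groups, so compound 4 extends the flat picture at this position to a phenyl group with its substituent elsewhere on the ring. Nothing measured here accounts for this flatness. As far as these compounds go, it remains open whether 4-chlorophenyl would read level with compound 4, and whether a carboxylic acid or a morpholine on this ring would move the number beyond the scatter.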